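This account rests on a few compounds, and the source may have more. Where it says the series, first, only, none or still open, it means among the compounds named here.

Measured so far in an ADME assay on GES1 cells (Homo sapiens) for inhibition, read by MTT assay, with a stated time of 72 h; a higher number here means a weaker inhibitor, a lower number a stronger inhibitor:
compound 1 `Cc1cc(Nc2ccn(Cc3ccccc3)n2)n2nc(SCc3ccc(Br)cc3)nc2n1`: 44400 nM
compound 2 `Cc1cc(Nc2cc(-c3ccccc3)[nH]n2)n2nc(SCc3ccc(Br)cc3)nc2n1`: 39300 nM
compound 3 `Cc1cc(Nc2cc(C(C)(C)C)[nH]n2)n2nc(SCc3ccc(Br)cc3)nc2n1`: a limit only, > 50000 nM

Compound 2 has the lowest of the two numbers shown, but compound 1 sits within the scatter of it, so no order between them can be read. Compound 3 gives only a limit, (the limit of > 50000 nM in this assay, at which 1 of the 3 values shown sits). Among the compounds with values here, the one measured step, an at least 1.2-fold higher number from compound 2 to compound 3 (0.10 log units; that floor lies within the scatter), changes a group elsewhere in the molecule and stays within the scatter.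

Compound 4 `Cc1cc(Nc2cc(-c3ccccc3)[nH]n2)n2nc(SCc3csc4ccccc34)nc2n1` differs from compound 2 by 1-benzothiophen-3-yl in place of 4-bromophenyl on a saturated chain carbon bound to a sulfur. No measured step touches this position, so nothing shown bears directly on it; with the only measured step within the scatter, no change beyond the scatter is expected, a 1.0-fold higher number from compound 2 to compound 4 (0.01 log units; within the scatter). Compound 4 is estimated at 40000 nM, between 18000 nM and 90000 nM.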

Compound 4, half-maximal inhibitory concentration: 29200 nM
Beside the measured number, compound 4's estimate is 1.4-fold (0.14 log units) above it; the range from low to high includes it.
By their numbers in this assay, from the lowest: compounds 4, 2 and 1 (each within the scatter of the next). At a limit, above all of these: compound 3.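

Within the data shown here, the only step read at the saturated chain carbon bound to a sulfur, 1-benzothiophen-3-yl in place of 4-bromophenyl, gives in this assay a 1.3-fold lower number from compound 2 to compound 4 (0.13 log units; within the scatter). Replacing the bromine-bearing ring with one that adds a five-membered aromatic ring with a hetero atom therefore leaves the number within the scatter. Nothing at hand accounts for the size of this step.

On these data alone, whether an amine or a carboxylic acid on the aromatic ring at this position would move the number beyond the scatter remains open. So does the effect of a longer chain in place of the 4-bromobenzyl group.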